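Isopropyl on the amidine across two benzofuran-free cores

This account rests on a few compounds, and the source may have more. Where it says the series, first, only, none or still open, it means among the compounds named here.

Four compounds form the set. Compound 1 has the structure `N=C(N)c1ccc2oc(-c3cccc(OCCCOc4ccccc4)c3)cc2c1`; compound 2 is `CC(C)NC(=N)c1ccc2oc(-c3cccc(OCCCOc4ccccc4)c3)cc2c1`; compound 3 is `N=C(N)c1ccc2oc(-c3cccc(OCCCCCOc4ccccc4)c3)cc2c1`; and compound 4, not yet measured, is `CC(C)NC(=N)c1ccc2oc(-c3cccc(OCCCCCOc4ccccc4)c3)cc2c1`. In an ADME assay on L6 cells (Rattus norvegicus) for cytotoxicity, read by resazurin assay, with a stated time of 70 h (a higher number here means a weaker inhibitor, a lower number a stronger inhibitor), compound 1 gives 10300 nM, compound 2 gives 26500 nM, and compound 3 gives 3000 nM, the lowest of the three numbers.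

The change from compound 1 to compound 2 is isopropyl in place of hydrogen on an amine nitrogen, and it brought a 2.6-fold higher number from compound 1 to compound 2 (0.41 log units; beyond the scatter). The cores of compound 1 and compound 3 differ by 2-phenoxyethyl in place of phenoxy on a saturated chain carbon, three bonds along the chain from an oxygen on an aromatic ring, a change that gave a 3.4-fold lower number from compound 1 to compound 3 (0.54 log units; beyond the scatter).

Compound 4 carries the same change on the core of compound 3: isopropyl in place of hydrogen on an amine nitrogen. The place of the change, an amine nitrogen whose other neighbour is a carbon with a double bond to nitrogen, is the same in both pairs, so it is taken as the same change. Among the compounds with values here, compound 4 is therefore expected to show a 2.6-fold higher number from compound 3 to compound 4 (0.41 log units; beyond the scatter), resting on the single earlier step of a 2.6-fold higher number from compound 1 to compound 2 (0.41 log units; beyond the scatter); with only one precedent the expectation is held loosely. Compound 4 is estimated at 7800 nM, most likely between 3500 nM and 17000 nM.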

Compound 4, half-maximal inhibitory concentration: 10100 nM
Estimate against measurement, compound 4: 1.3-fold (0.11 log units) below; measured number inside the range.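

In this assay isopropyl in place of hydrogen on an amine nitrogen brought a 3.4-fold higher number from compound 3 to compound 4 (0.53 log units; beyond the scatter), and the size of this step held from one core to the other: the same change on two cores in this assay, a 2.6-fold higher number (0.41 log units; beyond the scatter) from compound 1 to compound 2 and a 3.4-fold higher number (0.53 log units; beyond the scatter) from compound 3 to compound 4, 1.3-fold (0.12 log units) apart, within the scatter of two such steps
The other change, 2-phenoxyethyl in place of phenoxy on a saturated chain carbon, brought a 2.6-fold lower number from compound 2 to compound 4 (0.42 log units; beyond the scatter) with isopropyl present, and it too kept its size: the same change on two cores in this assay, a 3.4-fold lower number (0.54 log units; beyond the scatter) from compound 1 to compound 3 and a 2.6-fold lower number (0.42 log units; beyond the scatter) from compound 2 to compound 4, 1.3-fold (0.12 log units) apart, within the scatter of two such steps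
Within these four compounds and this one assay the two changes therefore behave as if independent of each other, but two pairs per change do not show that either would carry to a core outside this set.

The compounds shown leave open whether a methyl or a cyclopentyl on the same amine nitrogen would give a step like that of isopropyl. They also leave open whether the isopropyl step would keep its size on a longer chain.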